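Para substituent change on the aryl ring of the shared core

The compounds below may be only part of what the source reports. "The series", "measured", "known", "first", "only" and "open" are said of these compounds alone.

Compound 2 `CCOC(=O)C1=C(C)NC(=S)NC1c1ccc(OC)cc1` stands lowest of the three numbers recorded in a functional assay on NCI-H460 cells (Homo sapiens) for inhibition, read by sulforhodamine B assay, with a stated time of 48 h (on this read-out lower numbers stand for stronger inhibition of growth and higher numbers for weaker inhibition of growth), where compound 2 gives 31.4 ug/mL. Its nearest neighbour is compound 1 `CCOC(=O)C1=C(C)NC(=S)NC1c1cc(OC)c(O)c(OC)c1`, which in this assay gives 65.6 ug/mL, and the furthest is compound 3 `CCOC(=O)C1=C(C)NC(=S)NC1c1ccc(O)c(OC)c1`, which in this assay gives 180 ug/mL.

Compound 4 `CCCc1ccc(C2NC(=S)NC(C)=C2C(=O)OCC)cc1` is derived from compound 2 by propyl in place of methoxy on an aromatic carbon. Going by the values given here, the only single-point step measured so far is a 2.7-fold higher number from compound 1 to compound 3 (0.44 log units; beyond the scatter), which removes a methoxy from the aryl ring of the shared core rather than exchanging it for a propyl, so it bears on the present change only loosely: it shows that altering the substitution on that ring moves the number by a modest amount, without telling the direction for a propyl. Among the compounds with values here, no pair among compounds 1 to 3 isolates the para position alone.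

The expectation for compound 4 is therefore a step within or just beyond the scatter in this assay, direction uncertain, best set close to the value of compound 2: the estimate is 28 ug/mL, range 10 ug/mL to 75 ug/mL, meaning an expected step of a 1.1-fold lower number from compound 2 to compound 4 (0.05 log units; within the scatter).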

Compound 4, concentration for 50% growth inhibition: 22.5 ug/mL
Compound 4: middle estimate off by 1.2-fold (0.09 log units), on the high side; the range from low to high includes it.
By their numbers in this assay, from the lowest: compounds 4 and 2 (each within the scatter of the next); then compound 1; then compound 3.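

In this assay, going by these compounds alone, propyl in place of methoxy on an aromatic carbon para to a large group gives a 1.4-fold lower number from compound 2 to compound 4 (0.14 log units; within the scatter), the only single-place reading at this position, which the earlier compounds could not supply. At this position, therefore, a methoxy with its one hydrogen-bond acceptor and a propyl with none give numbers that cannot be told apart, so in this pair the acceptor count of the substituent and the presence of oxygen leave no mark beyond the scatter, unlike the removal of methoxy in a 2.7-fold higher number from compound 1 to compound 3 (0.44 log units; beyond the scatter), a step at another place on a differently substituted ring. No measurement of any property of these compounds is available to explain the result.

From the compounds shown here alone, it remains open whether this tolerance extends to groups of a different kind at the same place, such as an amine, a carboxylic acid or a longer chain like hexyl, or whether one of them would move the number beyond the scatter. Also open, going by these compounds, is whether the same exchange would read alike on the more heavily substituted ring of compound 1, which carries a hydroxyl and two methoxy groups.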